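This account rests on a few compounds, and the source may have more. Where it says the series, first, only, none or still open, it means among the compounds named here.

Of the compounds shown here, three sharing one core have been measured in a functional assay on MCF7 cells (Homo sapiens) for antiproliferative activity, read by CCK-8 assay, with a stated time of 48 h; a lower number here means a stronger inhibitor, a higher number a weaker inhibitor. Compound 1 `O=c1c2ccccc2[se]n1-c1nnc(-c2ccc(Br)cc2)s1` carries a 4-bromophenyl and gives 43300 nM, the highest number of the three. Compound 2 `O=c1c2ccccc2[se]n1-c1nnc(-c2ccc(Cl)cc2)s1`, with a 4-chlorophenyl, gives 19500 nM, and compound 3 `O=c1c2ccccc2[se]n1-c1nnc(-c2ccccc2Cl)s1`, with a 2-chlorophenyl, gives 4430 nM, the lowest of the three. Compound 4 `Cc1ccccc1-c1nnc(-n2[se]c3ccccc3c2=O)s1` has not yet been measured. Its change from compound 1 is 2-methylphenyl in place of 4-bromophenyl on an aromatic carbon. Among the compounds with values here, two measured steps bear on this. The step of a 2.2-fold lower number from compound 1 to compound 2 (0.35 log units; beyond the scatter) shows that exchanging the halogen on the 4-bromophenyl changes the number only modestly, while a 9.8-fold lower number from compound 1 to compound 3 (0.99 log units; beyond the scatter) and a 4.4-fold lower number from compound 2 to compound 3 (0.64 log units; beyond the scatter) show that a 2-chlorophenyl gives a clearly lower number than either 4-halophenyl. Within the data shown here, no compound with a 2-methylphenyl has been measured, so the difference between a chloro and a methyl on that ring is unknown. A lower number than compound 1 is expected, a 6.2-fold lower number from compound 1 to compound 4 (0.79 log units; beyond the scatter), in the direction set by compound 3 with 4430 nM. Compound 4 is estimated at 7000 nM, with a range from 2000 nM to 25000 nM.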

Compound 4, half-maximal inhibitory concentration: 36800 nM
The estimate for compound 4 lay 5.3-fold (0.72 log units) below the measured number, outside the stated range (above it).
By their numbers in this assay, from the lowest: compound 3; then compounds 2, 4 and 1 (each within the scatter of the next, the first and the last beyond it).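

In this assay, the 2-methylphenyl does not bring the low number seen with the 2-chlorophenyl: methyl for chloro gives an 8.3-fold higher number from compound 3 to compound 4 (0.92 log units; beyond the scatter) and so separates the two groups clearly. Compound 4 also cannot be told apart from the 4-halophenyl compounds, as a 1.2-fold lower number from compound 1 to compound 4 (0.07 log units; within the scatter) and a 1.9-fold higher number from compound 2 to compound 4 (0.28 log units; within the scatter) both show, so the low number of compound 3 stands alone among these four and does not follow from any group placed as in the 2-chlorophenyl. No measurement here explains why chloro and methyl part ways.

As far as these compounds go, whether a methoxy group, an amine or a carboxylic acid on that phenyl ring would behave like the chloro or like the methyl remains open. Also open, from the compounds shown here alone, is how a 2-bromophenyl or a plain phenyl would compare with compound 3.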